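Swapping Methoxy for Bromo on the Sulfonyl Ring

This account rests on a few compounds, and the source may have more. Where it says the series, first, only, none or still open, it means among the compounds named here.

Three compounds share one core and differ only in the group on the ring attached to the sulfonyl. Compound 1 `CCCc1nc2c(C)cc(-c3nc4ccccc4n3C)cc2n1S(=O)(=O)c1ccccc1` carries no extra group there; in a functional assay on A549 cells (Homo sapiens) for cytotoxicity, read by MTT assay (on this read-out lower numbers stand for stronger inhibition and higher numbers for weaker inhibition), compound 1 gives > 50000 nM, which is a limit of the assay rather than a number. Compound 2 `CCCc1nc2c(C)cc(-c3nc4ccccc4n3C)cc2n1S(=O)(=O)c1ccc(C)cc1` carries a methyl on that ring; in this assay compound 2 gives > 50000 nM, again only a limit. Going by the values given here, compound 3 `CCCc1nc2c(C)cc(-c3nc4ccccc4n3C)cc2n1S(=O)(=O)c1ccc(OC)cc1` carries a methoxy, and in this assay compound 3 gives 34700 nM, the only real number in the set. The two steps into it are an at least 1.4-fold lower number from compound 1 to compound 3 (0.15 log units; that floor lies within the scatter) and an at least 1.4-fold lower number from compound 2 to compound 3 (0.15 log units; that floor lies within the scatter); both floors sit within the scatter, so compound 3 stands only marginally apart from the others, and the limit of > 50000 nM in this assay, at which 2 of the 3 values shown sit, marks where the rest sit. Compound 4 `CCCc1nc2c(C)cc(-c3nc4ccccc4n3C)cc2n1S(=O)(=O)c1ccc(Br)cc1` is the next variation: bromo in place of methoxy on an aromatic carbon. Among the compounds with values here, no measured step removes a methoxy or introduces a bromo, so the only guidance is that the methoxy compound is the sole one with a readable number, and giving up the methoxy may give that up too. For compound 4 the expected step is a 1.3-fold higher number from compound 3 to compound 4 (0.11 log units; within the scatter), toward weaker inhibition. The estimated value of compound 4 in this assay is 45000 nM, between 15000 nM and 120000 nM, with a fair chance that only a limit is reported.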

Compound 4, half-maximal inhibitory concentration: 35100 nM
Estimate against measurement, compound 4: 1.3-fold (0.11 log units) above; low and high end bracket the measured number.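

Exchanging the methoxy for bromo, on the aromatic carbon para to a large group, gives in this assay a 1.0-fold higher number from compound 3 to compound 4 (0.00 log units; within the scatter), so a readable number at this position does not depend on the methoxy or on the hydrogen-bond acceptor counted in it. Set against the two other compounds, the bromo compound shows an at least 1.4-fold lower number from compound 2 to compound 4 (0.15 log units; that floor lies within the scatter) and an at least 1.4-fold lower number from compound 1 to compound 4 (0.15 log units; that floor lies within the scatter), which means it stands only marginally apart from them, just as the methoxy compound did. Compound 1 and compound 2 still give only a limit of the assay and not a number: the limit of > 50000 nM in this assay, at which 2 of the 4 values shown sit.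

On these data alone, all of these floors lie within the scatter, so the true size of any gap between the two readable compounds and the two at the limit stays open, and the idea that a group at this place matters at all rests on thin ground. Whether a nitrile, an amine or a carboxylic acid on this ring would move the number beyond the scatter in either direction also remains unanswered.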